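Series notes: amine swap on the shared core

The source may report more compounds than this note shows. Statements on the series, on what has been measured and on what is new or still open speak of the compounds shown alone.

Compound 1 `CC(C)(C)c1ccnc(Cl)n1` and compound 2 `CC(C)(C)Nc1nccc(C(C)(C)C)n1` make up the measured pair. In a functional assay on the whole organism for inhibition, with Rattus norvegicus as the target, with stated times of 1 h and 3.5 h, at a dose of 100 mg/kg by the oral route (a lower number here means less inhibition, a higher number more inhibition at the dose given (going by the name of the read-out)), compound 1 gives only a limit, < 5%, not a number. In this assay compound 2 gives 26%. For the measured compounds named here, compound 2 therefore holds the only number seen so far; the other value is a limit, as noted in the limit of < 5% in this assay, at which 1 of the 2 values shown sits. Going by the values given here, the one measured step, a number at least 21 percentage points higher from compound 1 to compound 2 (beyond the scatter), is the whole record of how a change on that aromatic carbon moves the read-out.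

Compound 3 `CN(C)c1nccc(C(C)(C)C)n1` differs from compound 2 by dimethylamino in place of (tert-butyl)amino on an aromatic carbon. The measured step does not cover this change: it replaced chloro by an amine, whereas here one amine replaces another and the single hydrogen-bond donor goes out, as counted. Among the compounds with values here, no measured step therefore sets its size or direction; the only anchor is that compound 2 rose from compound 1 in a number at least 21 percentage points higher from compound 1 to compound 2 (beyond the scatter). The working expectation is a small move, more likely downward than upward, a number 11 percentage points lower from compound 2 to compound 3 (beyond the scatter), with a fair chance of a value within the scatter of compound 2. Compound 3 is thus estimated at 15%, range 0% to 35%, with some chance that only a limit is returned.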

Compound 3, a percentage reported as inhibition, in the whole organism at one dose (the size of the read-out at that dose, not a potency): 18%
For compound 3 the middle estimate is 3 percentage points below the measured one, within the range that was stated.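

In this assay, dimethylamino in place of (tert-butyl)amino on the aromatic carbon between two ring nitrogen atoms gives a number 8 percentage points lower from compound 2 to compound 3 (within the scatter), so the two amines cannot be told apart in this read-out, even though (tert-butyl)amino carries a hydrogen-bond donor and dimethylamino carries none. Dimethylamino in place of chloro gives a number at least 13 percentage points higher from compound 1 to compound 3 (beyond the scatter) and the read-out stays clear of the chloro compound, so the rise seen with compound 2 now appears with a second amine and, in this pair, without a hydrogen-bond donor on the amine. The size of that rise remains open-ended, since compound 1 gives a limit and not a number: the limit of < 5% in this assay, at which 1 of the 3 values shown sits.

From the compounds shown here alone, whether other groups at this carbon, such as the unsubstituted amino group, methylamino or a cyclic amine such as morpholine, would separate from compound 2 beyond the scatter remains open. The tert-butyl group is common to all three compounds, so what a methyl group or a phenyl ring at that place would do to the read-out is also unknown.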